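The source may hold more compounds than are shown below. What is called first, only, known or untested is meant among the compounds shown, and "the series" means these compounds.

Measured so far, in a functional assay on NCI/ADR-RES cells (Homo sapiens) for inhibition, read by sulforhodamine B assay, with a stated time of 48 h; a higher number here means a weaker inhibitor of growth, a lower number a stronger inhibitor of growth:
compound 1 `CC1=CC[C@H](C(C)(C)NC(=S)NN)CC1`: > 100000 nM
compound 2 `CC1=CC[C@H](C(C)(C)NC(=S)N/N=C/c2ccccc2Cl)CC1`: > 100000 nM
compound 3 `CC1=CC[C@H](C(C)(C)NC(=S)N/N=C/c2cccc(Cl)c2)CC1`: > 100000 nM

The value shown for compound 1 is a limit of the assay, not a number. The value shown for compound 2 is likewise a limit. The value shown for compound 3 is also a limit. All three therefore stand at the limit of > 100000 nM in this assay, at which 3 of the 3 values shown sit, and compound 1 cannot be placed more exactly than that. Within the data shown here, the one step between measured compounds, a step that the two limits leave unreadable from compound 2 to compound 3, is unreadable for the same reason.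

Compound 4 `CC1=CC[C@H](C(C)(C)NC(=S)N/N=C/c2ccc[nH]2)CC1` differs from compound 1 by a group of 7 heavy atoms (5 carbon, 2 nitrogen; one five-membered aromatic ring with 1 hetero atom) in place of one nitrogen atom, on an amide-type nitrogen. No measured step bears on this change, and no step shown rises above the scatter. Compound 4 is therefore expected to give about 200000 nM, most likely again a limit, within 50000 nM to 1000000 nM. The expected step that the limit leaves unreadable from compound 1 to compound 4 is no more than scatter.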

Compound 4, concentration for total growth inhibition: > 100000 nM
Compound 4 ended at the assay's limit (the forecaster's own chance of this, stated with the estimate: 85%); the middle value does not contradict the limit.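

No step can be read between compound 4 and compound 1, compound 2 or compound 3, because each value is a limit, not a number: the limit of > 100000 nM in this assay, at which 4 of the 4 values shown sit.

The compounds shown leave open whether these groups differ at all in their inhibition of growth.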